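The source may report more compounds than this note shows. Statements on the series, on what has been measured and on what is new or still open speak of the compounds shown alone.

Going by the values given here, compound 2, whose structure is `Cc1cccc(NC(=O)N[C@@H](C)c2ccccc2)c1`, gives the highest of the three numbers so far recorded in an ADME assay on the whole organism with Oryza sativa as the target, tested at 10 uM; on this read-out higher numbers stand for a weaker effect at the one concentration tested and lower numbers for a stronger effect: compound 2 shows 100%. Its closest neighbour on the scale is compound 1, drawn as `Cc1cccc(NC(=O)N[C@H](C)c2ccccc2)c1`, which in this assay reaches 47%. Compound 3, with structure `CCCCc1ccc(NC(=O)N[C@H](C)c2ccccc2)cc1`, lies furthest from compound 2 on the scale; in this assay compound 3 gives a reading of 28%. Among the compounds with values here, the one step so far measured between two compounds that differ in a single place is the one from compound 1 to compound 2, a number 53 percentage points higher from compound 1 to compound 2 (beyond the scatter), which rests on nothing more than the fact that compounds 1 and 2 differ only in the configuration as drawn.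

Compound 4, drawn as `C[C@H](NC(=O)Nc1cccc(F)c1)c1ccccc1`, differs from compound 2 in one place: fluoro in place of methyl on an aromatic carbon. Within the data shown here, none of the measured steps involves this kind of change, so no prior step can be carried over to it; the only measured step concerns configuration alone, and compound 3 differs from compound 1 in a way that stands apart from the exchange here. With no evidence of a change beyond the scatter, the expected step from compound 2 to compound 4 is a number 12 percentage points lower from compound 2 to compound 4 (beyond the scatter). Compound 4 is therefore estimated to give 88% in this assay, within a range from 55% to 100%.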

Compound 4, a percentage reported as activity, at one concentration (the size of the read-out at that concentration, not a potency): 88%
The estimate for compound 4 equals the measured number at the digits printed; low and high end bracket the measured number.
By their numbers in this assay, from the lowest: compound 3; then compound 1; then compound 4; then compound 2.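

In this assay, going by these compounds alone, fluoro in place of methyl on an aromatic carbon, meta to a large group, yields the first measured step that involves a change of substituent rather than of configuration alone (a number 12 percentage points lower from compound 2 to compound 4 (beyond the scatter)). The reading at this position therefore responds to the exchange of one single-atom group for another, even though the two groups match in heavy-atom count, in hydrogen-bond donors and acceptors, and in having no net charge. The step is modest, whereas the change of configuration alone produced a large one (a number 53 percentage points higher from compound 1 to compound 2 (beyond the scatter)), and nothing on record bears on why this exchange lowers the number, as the only fact available concerns configuration and not fluoro or methyl.

The compounds shown leave open whether a chloro group, a methoxy group or an amine on the same aromatic carbon would move the number further than fluoro does. They also leave open whether fluoro in place of methyl would give a step of similar size in the configuration drawn for compound 1, where the starting number is much lower.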